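The source may hold more compounds than are shown below. What is called first, only, known or untested is meant among the compounds shown, and "the series" means these compounds.

Measured compounds in a functional assay on the whole organism (strain albino) for inhibition, with Rattus norvegicus as the target, read by paw edema, with a stated time of 4 h, at a dose of 0.28 mmol/kg by the oral route; a higher number here means more inhibition at the dose given (going by the name of the read-out), a lower number less inhibition:

Compound 1, `C=CCn1c(SC/C(=N\O)c2ccccc2)nnc1-c1ccc(OC)c(OC)c1`, gives 78%.
Compound 2, `CCn1c(SCC(=O)c2ccccc2)nnc1-c1ccc(OC)cc1`, gives 70%.
Compound 3, `CCn1c(SCC(=O)c2ccccc2)nnc1-c1ccccc1`, gives 63%.

Compound 2 stands in the middle of these three numbers. Its nearest neighbour is compound 3, and the change from one to the other is a single one: a number 7 percentage points lower from compound 2 to compound 3 (within the scatter). Compound 1 lies on the other side of compound 2, also within the scatter, but compound 1 differs from compound 2 in more than one place, so no single step can be read from that pair.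

Compound 4, `CCn1c(SCC(=O)c2ccccc2)nnc1-c1ccc(OC)c(OC)c1`, has not yet been measured. The change from compound 2 is methoxy in place of hydrogen on an aromatic carbon. For the measured compounds named here, the only step that speaks to this change is the one from compound 2 to compound 3, which moved the opposite way, removing a methoxy group, and stayed within the scatter. Adding a methoxy group is therefore expected to move the number little, if at all, in this assay, perhaps a few points upward, as the step from compound 2 to compound 4 is expected to be a number 4 percentage points higher from compound 2 to compound 4 (within the scatter). The expected value for compound 4 is 74%, with a range from 62% to 86%.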

Compound 4, a percentage reported as inhibition, in the whole organism at one dose (the size of the read-out at that dose, not a potency): 73%
Estimate against measurement, compound 4: 1 percentage points above, within the range that was stated.
By their numbers in this assay, from the lowest: compounds 3, 2, 4 and 1 (each within the scatter of the next, the first and the last beyond it).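

In this assay, a methoxy group at this place on the aromatic ring, ortho to a methoxy group and meta to a large group, gives no change that can be told from the usual scatter: the step is a number 3 percentage points higher from compound 2 to compound 4 (within the scatter). For the compounds shown here, the earlier step, a number 7 percentage points lower from compound 2 to compound 3 (within the scatter), concerned the methoxy group already present in compound 2, so this is the first reading at this second place on the ring, and it too stays within the scatter. What lies behind the small size of this step cannot be said from the information at hand.

On these data alone, whether a different group at this same place, such as a hydroxyl group, a chlorine atom, an amine or a longer alkoxy chain, would move the number beyond the scatter remains open. These numbers also show the size of the effect at a single dose and a single time, so they leave open whether adding the methoxy group would make a difference at a lower dose or at a later time.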